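A Smaller Terminal Group on the Amine Nitrogen

The source may report more compounds than this note shows. Statements on the series, on what has been measured and on what is new or still open speak of the compounds shown alone.

Compound 1 `CCC/N=C(/NC#N)NCCCn1nc(-c2ccccc2)ccc1=O` was examined in a functional assay on the whole organism (stomach) with Rattus norvegicus as the target (a higher number here means that more compound is needed for the effect, a lower number that less compound is needed), where compound 1 gives 100 mg/kg. Within the data shown here, this is the only plain number in the set. Compound 2 `O=c1ccc(-c2ccccc2)nn1CCCCNC(=S)Nc1cccc2ccccc12` reaches only a limit, > 100 mg/kg. Compound 3 `C/N=C(/NC#N)NCCCCCn1nc(-c2ccccc2)c(C)cc1=O` likewise reaches only a limit, > 100 mg/kg. Two of the three values therefore sit at the limit of > 100 mg/kg in this assay, at which 2 of the 3 values shown sit. Compound 4 `N#CNC(=N)NCCCn1nc(-c2ccccc2)ccc1=O` has not yet been measured in this assay. Compound 4 differs from compound 1 at one place: a group of 5 heavy atoms (2 carbon, 3 nitrogen; no ring) in place of a group of 8 heavy atoms (5 carbon, 3 nitrogen; no ring), on an amine nitrogen. Among the measured compounds shown here, no measured pair differs at a single place, so the size of such a step is not known from the data. Because compound 1 already gives 100 mg/kg, the expected step is a 1.5-fold higher number from compound 1 to compound 4 (0.18 log units; within the scatter), toward a higher dose, with a result within scatter quite possible. Compound 4 is estimated at 150 mg/kg, between 50 mg/kg and 500 mg/kg.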

Compound 4, dose for half-maximal effect: > 100 mg/kg
Compound 4: no number, only a limit; the forecaster's own chance of this, stated with the estimate: 55%; the middle value does not contradict the limit.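

Among these compounds, at this amine nitrogen, the first comparison that differs in one place gives a number no lower from compound 1 to compound 4 (the limit leaves the size open). The smaller group on the amine nitrogen therefore brings no lower number in this assay. Compound 4 now stands with the other compounds that reach only a limit: the limit of > 100 mg/kg in this assay, at which 3 of the 4 values shown sit.

As far as these compounds go, the size of the step stays open, and so does whether compound 4 differs from compound 1 beyond the usual scatter. From the compounds shown here alone, whether a longer chain or a benzyl group on this nitrogen would give a lower number than compound 1 also remains open.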